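The source may hold more compounds than are shown below. What is called first, only, known or untested is meant among the compounds shown, and "the series" means these compounds.

Measured compounds:
compound 1, `CC1=C(/C=C/C(=O)/C=C/c2ccccc2)C(C)(C)CCC1O`, 15500 nM;
compound 2, `CC1=C(/C=C/C(=O)/C=C/c2ccc(C(F)(F)F)cc2)C(C)(C)CCC1O`, 10200 nM;
compound 3, `CC1=C(/C=C/C(=O)/C=C/c2ccccc2F)C(C)(C)CCC1O`, 10400 nM.

All three values come from a functional assay on PC-3 cells (Homo sapiens) for cytotoxicity, read by MTT assay, with a stated time of 72 h; a lower number here means a stronger inhibitor, a higher number a weaker inhibitor. Compound 2 arises from compound 1 by trifluoromethyl in place of hydrogen on an aromatic carbon, and this step gave a 1.5-fold lower number from compound 1 to compound 2 (0.18 log units; within the scatter). Compound 3 arises from compound 1 by fluoro in place of hydrogen on an aromatic carbon, giving a 1.5-fold lower number from compound 1 to compound 3 (0.17 log units; within the scatter). Compounds 2 and 3 sit at values that are indistinguishable within the scatter.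

Compound 4, `CC1=C(/C=C/C(=O)/C=C/c2cccc(C(F)(F)F)c2F)C(C)(C)CCC1O`, is not yet measured. It arises from compound 3 by trifluoromethyl in place of hydrogen on an aromatic carbon. This is the same kind of change as that from compound 1 to compound 2, though not the same: there the entering group sat para to a large group, here it sits ortho to a fluoro group and meta to a large group. Because the earlier step was a 1.5-fold lower number from compound 1 to compound 2 (0.18 log units; within the scatter), the step from compound 3 to compound 4 in this assay is expected to be small, about a 1.4-fold lower number from compound 3 to compound 4 (0.14 log units; within the scatter). Compound 4 is estimated at 7500 nM, with a range from 3000 nM to 19000 nM.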

Compound 4, half-maximal inhibitory concentration: 2100 nM
Estimate against measurement, compound 4: 3.6-fold (0.55 log units) above, outside the stated range (below it).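

In this assay, trifluoromethyl in place of hydrogen on an aromatic carbon, ortho to a fluoro group and meta to a large group, gave a 5.0-fold lower number from compound 3 to compound 4 (0.69 log units; beyond the scatter). The size of this change therefore does not carry unchanged from one core to another in this series: the same change on two cores in this assay, a 1.5-fold lower number (0.18 log units; within the scatter) from compound 1 to compound 2 and a 5.0-fold lower number (0.69 log units; beyond the scatter) from compound 3 to compound 4, 3.3-fold (0.51 log units) apart, beyond the scatter of two such steps This does not show what sets the size of the step, since the two steps differ both in where the trifluoromethyl enters and in the fluoro group already present on the ring.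

Still open, from the compounds shown here alone, is whether the larger step requires that fluoro group or follows from the place of entry alone. Also open, going by these compounds, is whether a chloro or methoxy group entering at that place would give a similar step.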